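This account rests on a few compounds, and the source may have more. Where it says the series, first, only, none or still open, it means among the compounds named here.

Compound 1 `CCC(=O)Nc1c(C(O)(C(F)(F)F)C(F)(F)F)ccc2ccccc12` gives 8.91 nM in a functional assay (Sus scrofa) with sulfonylurea receptors; K-ATP channels (Homo sapiens) as the target; a lower number here means that less compound is needed, a higher number that more compound is needed for the effect. Compound 2 `CCCC(=O)Nc1c(C(O)(C(F)(F)F)C(F)(F)F)ccc2ccccc12` gives 708 nM. Compound 3 `O=C(Nc1c(C(O)(C(F)(F)F)C(F)(F)F)ccc2ccccc12)c1cccc([N+](=O)[O-])c1` gives 427 nM.

Among these three numbers compound 3 stands second highest: the step of a 1.7-fold lower number from compound 2 to compound 3 (0.22 log units; within the scatter) lies within the scatter, whereas the step of a 48-fold higher number from compound 1 to compound 3 (1.68 log units; beyond the scatter) is large. Compound 4 `O=C(Nc1c(C(O)(C(F)(F)F)C(F)(F)F)ccc2ccccc12)c1cnco1` differs from compound 3 by 1,3-oxazol-5-yl in place of 3-nitrophenyl on a carbonyl carbon. Going by the values given here, no measured step exchanges one aromatic group on the carbonyl carbon for another; the two steps that reach compound 3 replace a short chain with the 3-nitrophenyl group, and both end at a high number. Whether the 1,3-oxazol-5-yl group brings the number back toward compound 1 or leaves it near compound 3 cannot be read from these data. For compound 4 the step of a 1.7-fold lower number from compound 3 to compound 4 (0.23 log units; within the scatter) is expected, giving an estimated 250 nM with a range of 50 nM to 1500 nM.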

Compound 4, half-maximal effective concentration: 302 nM
Beside the measured number, compound 4's estimate is 1.2-fold (0.08 log units) below it; low and high end bracket the measured number.
By their numbers in this assay, from the lowest: compound 1; then compounds 4, 3 and 2 (each within the scatter of the next, the first and the last beyond it).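

In this assay, going by these compounds alone, the only exchange of one aromatic ring for another on the carbonyl carbon, a 1.4-fold lower number from compound 3 to compound 4 (0.15 log units; within the scatter), shows that the five-membered 1,3-oxazol-5-yl and the six-membered 3-nitrophenyl cannot be told apart here. Compared with the chains, the oxazole compound differs from the propyl compound by only a modest step, a 2.3-fold lower number from compound 2 to compound 4 (0.37 log units; beyond the scatter), but stays far from the ethyl compound, a 34-fold higher number from compound 1 to compound 4 (1.53 log units; beyond the scatter), so neither aromatic ring comes close to compound 1. Still open, going by these compounds, is what a methyl, a cyclopropyl or a plain phenyl on the carbonyl carbon would give, and so whether the low number of compound 1 belongs to ethyl alone. Nothing measured here explains these steps.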